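Replacing a carboxy group in a T-type channel series

A few compounds are considered here, and "the series" means these few. Any claim that something is new, unique, unknown or untested is made for them only; others in the source may bear on it.

Measured so far:
Compound 1, `CC(=O)N(CCCN(C)S(=O)(=O)c1ccc(Oc2ccccc2)cc1)Cc1cccc(Cl)c1`: 30%
Compound 2, `CN(CC(=O)Nc1cccc(S(=O)(=O)N(CC(=O)O)c2cccc(Cl)c2)c1)C(=O)OCc1ccccc1`: 11%

Both compounds were tested in a functional assay on HEK293 cells for antagonist activity at Voltage-dependent T-type calcium channel subunit alpha-1H (Homo sapiens), read by patch clamp, tested at 1 uM; on this read-out higher numbers stand for more inhibition at the one concentration tested (going by the name of the read-out) and lower numbers for less inhibition. Compound 1 gives 30%, and compound 2 gives 11%, the lowest of the two numbers and beyond the scatter below compound 1. The two compounds differ in more than one place, so their values are simply two readings, and nothing is known about what produces the gap between them.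

Compound 3, `CN(C)CCNC(=O)CN(c1cccc(Cl)c1)S(=O)(=O)c1cccc(NC(=O)CN(C)C(=O)OCc2ccccc2)c1`, has not yet been measured. It differs from compound 2 in one place: (2-(dimethylamino)ethyl)amino in place of hydroxy on a carbonyl carbon. Among the measured compounds shown here, no measured pair shows what such a change does, so the expectation rests only on the value of compound 2, 11%, which leaves little room for a fall and some room for a rise. The step expected in this assay is a number 14 percentage points higher from compound 2 to compound 3 (beyond the scatter), a modest rise with wide uncertainty. Compound 3 is estimated at 25%, with a range from 0% to 55%.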

Compound 3, a percentage reported as inhibition, at one concentration (the size of the read-out at that concentration, not a potency): 22%
Beside the measured number, compound 3's estimate is 3 percentage points above it; measured number inside the range.
By their numbers in this assay, from the lowest: compound 2; then compounds 3 and 1 (each within the scatter of the next).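

Among the compounds shown here, compound 2 and compound 3 are the first pair here that differ in one place only, so this assay can now be read for a single change. Putting (2-(dimethylamino)ethyl)amino in place of hydroxy on a carbonyl carbon gives a number 11 percentage points higher from compound 2 to compound 3 (beyond the scatter), a modest move that goes up, not down. This shows that the hydroxy at this place is not required for the inhibition seen at the one concentration tested, and that a group of 6 heavy atoms can stand there without that inhibition being lost, though nothing available explains why the number moves.

The new group brings several features at once, so this single step cannot show whether the gain comes from the amide link, the ethyl chain or the dimethylamino group. As far as these compounds go, a simple primary amide, a methyl ester or a longer chain ending in a piperidine would help separate these parts, and it also remains open whether the same change would have a similar effect on the core of compound 1.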